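From compound 1 to compound 3: expected step

The compounds below may be only part of what the source reports. "The series", "measured", "known", "first", "only" and "open" are said of these compounds alone.

In an ADME assay on HEL cells (Homo sapiens) for cytotoxicity (a higher number here means that more compound is tolerated, a lower number that less compound is tolerated), compound 1 `O=C(COc1cccc2ccccc12)N/N=C/c1cccc(O)c1` gives 62.7 ug/mL. Within the data shown here, compound 2 `O=C(COc1cccc2ccccc12)N/N=C/c1cccc([N+](=O)[O-])c1` gives 61.2 ug/mL, so the only two measured compounds sit level. Among the measured compounds shown here, the single measured step, a 1.0-fold lower number from compound 1 to compound 2 (0.01 log units; within the scatter), puts nitro in place of hydroxy on an aromatic carbon and stays within the scatter.

For the measured compounds named here, compound 3 `CSc1ccc(/C=N/NC(=O)COc2cccc3ccccc23)cc1` has no measurement yet. Its change from compound 1 is 4-(methylsulfanyl)phenyl in place of 3-hydroxyphenyl on a carbon with a double bond to nitrogen. Going by the values given here, the measured step bears on this only in part: it also removes the hydroxy, but no measured compound carries 4-(methylsulfanyl)phenyl. No step beyond the scatter is therefore expected, in either direction, and the range stays wide.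

The expected step is a 1.1-fold lower number from compound 1 to compound 3 (0.06 log units; within the scatter). For compound 3 the estimated value is 55 ug/mL, with an expected range of 20 ug/mL to 100 ug/mL.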

Compound 3, half-maximal cytotoxic concentration: > 100 ug/mL
Compound 3: only a limit was reported; the forecaster's own chance of this, stated with the estimate: 15%; at least 1.8-fold (0.25 log units) between middle value and limit.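

In this assay compound 3 gives > 100 ug/mL, which is a limit of the assay and not a number. Exchanging the aryl group of compound 1 for that of compound 3 gives an at least 1.5-fold higher number from compound 1 to compound 3 (0.20 log units; that floor lies within the scatter), so the floor alone does not separate the two compounds, yet the step has no upper bound, unlike the closed reading of a 1.0-fold lower number from compound 1 to compound 2 (0.01 log units; within the scatter). This position therefore can no longer be read as level across all changes, and the reading of this change is capped: the limit of > 100 ug/mL in this assay, at which 1 of the 3 values shown sits.

As far as these compounds go, compound 3 replaces the whole aryl group, so the loss of the hydroxy and the entry of the methylsulfanyl cannot be told apart, and the true size of the step stays unknown. An amine or a carboxylic acid on the aromatic ring in this place would show how far the number depends on this group.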